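Swapping the ring at one end of a shared core

The compounds below may be only part of what the source reports. "The series", "measured", "known", "first", "only" and "open" are said of these compounds alone.

Compounds measured so far:
compound 1 `c1ccc(-c2ccc(CCc3nc(CC4CCCC4)c[nH]3)cc2)nc1`, 177 nM 
compound 2 `CCC(C)(C)Cc1c[nH]c(CCc2ccc(-c3csnn3)cc2)n1`, 45 nM 
compound 3 `CCC(C)(C)Cc1c[nH]c(CCc2ccc(N3CCCCC3)cc2)n1`, 28 nM 

In an in vitro assay on CHO cells for displacement of a labelled ligand from Bombesin receptor subtype-3 (Homo sapiens), read by scintillation counting, with a stated time of 2 h (a higher number here means a weaker inhibitor, a lower number a stronger inhibitor), compound 3 has the lowest number of the three, though its gap to compound 2 sits within the scatter; only compound 1 stands clearly apart. Compound 4 `CCC(C)(C)Cc1c[nH]c(CCc2ccc(-c3cccnc3C(=O)O)cc2)n1` is not yet measured; it differs from compound 3 by 2-carboxypyridin-3-yl in place of piperidin-1-yl on an aromatic carbon. Among the measured compounds shown here, one measured step touches the same position: a 1.6-fold lower number from compound 2 to compound 3 (0.21 log units; within the scatter), a change within the scatter. That step offers little guidance for a carboxylic acid entering here, and compound 1 differs in two places, so only its value can be noted. A modest weakening is expected, with wide uncertainty, as a 2.9-fold higher number from compound 3 to compound 4 (0.46 log units; beyond the scatter). Compound 4 is estimated at 80 nM, between 20 nM and 400 nM.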

Compound 4, half-maximal inhibitory concentration: 560 nM
Compound 4: the middle estimate sits 7.0-fold (0.85 log units) below what was measured, and the stated range ends below it.
By their numbers in this assay, from the lowest: compounds 3 and 2 (each within the scatter of the next); then compound 1; then compound 4.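

Piperidin-1-yl and 1,2,3-thiadiazol-4-yl sit within the scatter of each other, yet this position does not accept every ring equally: 2-carboxypyridin-3-yl brings a 20-fold higher number from compound 3 to compound 4 (1.30 log units; beyond the scatter) and a 12-fold higher number from compound 2 to compound 4 (1.09 log units; beyond the scatter) in this assay. Nothing available explains this weakening. The change brings in a pyridine ring and a carboxylic acid together, so the compounds shown cannot separate their contributions. A plain pyridin-3-yl group or the methyl ester of the acid would be needed to tell them apart.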